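Removing One Acetyl Group: Expected Solubility of Compound 3

The compounds below may be only part of what the source reports. "The series", "measured", "known", "first", "only" and "open" are said of these compounds alone.

Compound 1: `COc1ncnc2c1ncn2[C@@H]1O[C@H](COC(C)=O)[C@@H](OC(C)=O)[C@@H]1OC(C)=O` — 81800000 nM
Compound 2: `COc1ncnc2c1ncn2[C@@H]1O[C@H](CO)[C@@H](OC(C)=O)[C@@H]1OC(C)=O` — 172000000 nM

Both compounds were measured in a physicochemical assay for solubility, in phosphate buffer; on this read-out lower numbers stand for lower solubility and higher numbers for higher solubility. Among the measured compounds shown here, compound 1 gives the lower of the two numbers, and the only neighbouring step is a 2.1-fold higher number from compound 1 to compound 2 (0.32 log units; beyond the scatter), a modest rise that goes with trading an acetyl for hydrogen on an oxygen on a saturated carbon.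

The unmeasured compound 3, `COc1ncnc2c1ncn2[C@@H]1O[C@H](COC(C)=O)[C@@H](OC(C)=O)[C@@H]1O`, differs from compound 1 by hydrogen in place of acetyl on an oxygen on a saturated carbon; cut one bond further out, the change reads acetoxy to hydroxy, here at the oxygen on a saturated ring carbon rather than at the chain oxygen. For the measured compounds named here, the one measured step that bears on this change is the same kind of swap, and it gave a 2.1-fold higher number from compound 1 to compound 2 (0.32 log units; beyond the scatter). A rise of similar size, in the same direction, is therefore expected for compound 3 in this assay, namely a 2.0-fold higher number from compound 1 to compound 3 (0.29 log units; within the scatter). Compound 3 is estimated at 160000000 nM, with a range from 90000000 nM to 300000000 nM.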

Compound 3, solubility: 12300000 nM
Beside the measured number, compound 3's estimate is 13-fold (1.11 log units) above it, and the stated range ends above it.
By their numbers in this assay, from the lowest: compound 3; then compound 1; then compound 2.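

In this assay, trading acetyl for hydrogen on an oxygen on a saturated carbon whose other neighbours are saturated ring carbon gives a 6.7-fold lower number from compound 1 to compound 3 (0.82 log units; beyond the scatter) and so moves the number down, while losing a different acetyl gave a 2.1-fold higher number from compound 1 to compound 2 (0.32 log units; beyond the scatter) and moved it up. The same kind of swap therefore goes in opposite directions at two places on one compound, so the outcome depends on which acetyl leaves, and a step at one place cannot simply be carried over to another. No measurement at hand accounts for this difference in direction.

Still open, going by these compounds, is how the remaining acetyl would behave if replaced by hydrogen. Also open, on these data alone, is what a methyl ether or an amine would give in place of the hydroxy at this position.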